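The source may hold more compounds than are shown below. What is called first, only, known or untested is meant among the compounds shown, and "the series" means these compounds.

In a functional assay on MDA-MB-231 cells (Homo sapiens) for antiproliferative activity, with a stated time of 5 days (on this read-out lower numbers stand for stronger inhibition and higher numbers for weaker inhibition), compound 1 (`O=C1C=CC2(C=C1)OCC(=O)N2c1nc(-c2ccc3c(c2)OCCO3)nn1-c1ccccc1`) gives 100 nM and compound 2 (`O=C1C=CC2(C=C1)OCC(=O)N2c1nc(-c2ccc3ccccc3c2)nn1-c1ccc(C(F)(F)F)cc1`) gives 70 nM, two values within the usual scatter of each other. For the measured compounds named here, compound 1 therefore cannot be separated from the only other measured compound. Compound 3 (`O=C1C=CC2(C=C1)OCC(=O)N2c1nc(-c2cccc(Cl)c2)nn1-c1ccccc1`) keeps the core of compound 1 and carries one change: 3-chlorophenyl in place of 2,3-dihydro-1,4-benzodioxin-6-yl on an aromatic carbon. Going by the values given here, no measured pair differing in one place is available to size this change, so no shift beyond the scatter is expected in this assay, and no direction is favoured. For compound 3 the estimated value is 120 nM, with an expected range of 40 nM to 350 nM.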

Compound 3, half-maximal inhibitory concentration: 0.8 nM
Compound 3: the middle estimate sits 150-fold (2.18 log units) above what was measured; measured number outside the range, below it.
By their numbers in this assay, from the lowest: compound 3; then compounds 2 and 1 (each within the scatter of the next).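

In this assay, for the compounds shown here, 3-chlorophenyl in place of 2,3-dihydro-1,4-benzodioxin-6-yl gives a 130-fold lower number from compound 1 to compound 3 (2.10 log units; beyond the scatter) and is the first sized change on this aromatic carbon, showing that the read-out responds strongly to the group placed there. The change removes the non-aromatic ring and both hydrogen-bond acceptors and adds chlorine, all in one step, and the step cannot be divided among these differences. Nothing available accounts for its size.

Still open, on these data alone, is whether the chlorine itself is needed, which unsubstituted phenyl on this carbon would test. Also open, as far as these compounds go, is whether a methoxy group or an amine in place of the chlorine would keep the number this low.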